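This account rests on a few compounds, and the source may have more. Where it says the series, first, only, none or still open, it means among the compounds named here.

In a functional assay on UO-31 cells (Homo sapiens) for antiproliferative activity, with a stated time of 48 h (a higher number here means a weaker inhibitor of growth, a lower number a stronger inhibitor of growth), the three measured compounds give: compound 1 `Cc1cc(O)c(C2=NN(c3ccc(S(N)(=O)=O)cc3)C(c3ccccc3O)C2)cc1Cl`, 11600 nM; compound 2 `Cc1cc(O)c(C2=NN(c3ccc(S(N)(=O)=O)cc3)C(/C=C/c3ccccc3)C2)cc1Cl`, 34900 nM; compound 3 `COc1ccc(C2CC(c3cc(Cl)c(C)cc3O)=NN2c2ccc(S(N)(=O)=O)cc2)cc1OC`, 100000 nM.

Compound 2 stands second highest of the three, with compound 3 nearest at a 2.9-fold higher number from compound 2 to compound 3 (0.46 log units; beyond the scatter) and compound 1 furthest at a 3.0-fold higher number from compound 1 to compound 2 (0.48 log units; beyond the scatter). Compound 4 `COc1ccc(C2CC(c3cc(Cl)c(C)cc3O)=NN2c2ccc(S(N)(=O)=O)cc2)c(OC)c1OC` differs from compound 2 by 2,3,4-trimethoxyphenyl in place of 2-phenylethenyl on a saturated ring carbon. Among the measured compounds shown here, the step that bears most on this is the one to compound 3, where a methoxy-bearing phenyl in the same place gave a 2.9-fold higher number from compound 2 to compound 3 (0.46 log units; beyond the scatter); the step of an 8.6-fold higher number from compound 1 to compound 3 (0.94 log units; beyond the scatter) points the same way. A modest rise in this assay, beyond the scatter, is therefore expected, and compound 4 is estimated to show a 2.6-fold higher number from compound 2 to compound 4 (0.41 log units; beyond the scatter). Compound 4 is expected at about 90000 nM, with a range of 30000 nM to 200000 nM.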

Compound 4, concentration for total growth inhibition: 28900 nM
Compound 4: middle estimate off by 3.1-fold (0.49 log units), on the high side; measured number outside the range, below it.
By their numbers in this assay, from the lowest: compound 1; then compounds 4 and 2 (each within the scatter of the next); then compound 3.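

In this assay, one extra methoxy in place of hydrogen on an aromatic carbon is enough to separate two methoxy-bearing phenyl groups at this saturated ring carbon (a 3.5-fold lower number from compound 3 to compound 4 (0.54 log units; beyond the scatter)), so such groups cannot be treated as alike here. Meanwhile, 2,3,4-trimethoxyphenyl and 2-phenylethenyl cannot be told apart (a 1.2-fold lower number from compound 2 to compound 4 (0.08 log units; within the scatter)), and 2-hydroxyphenyl keeps the lowest number (a 2.5-fold higher number from compound 1 to compound 4 (0.40 log units; beyond the scatter)). Nothing available accounts for these differences. As far as these compounds go, it remains open how an amine, a carboxylic acid or a longer chain would behave at this carbon.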